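Methyl-to-fluoro swap on the aryl of compound 1

The source may hold more compounds than are shown below. What is called first, only, known or untested is meant among the compounds shown, and "the series" means these compounds.

Measured compounds in a functional assay on Huh-7 cells (Homo sapiens) for inhibition, read by sulforhodamine B assay, with a stated time of 72 h; on this read-out higher numbers stand for weaker inhibition and lower numbers for stronger inhibition:
- compound 1 `Cc1ccc(C2=Nn3c(nnc3C(C)c3ccc(CC(C)C)cc3)SC2)cc1`: 5000 nM
- compound 2 `COc1ccc2cc(C(C)c3nnc4n3N=C(c3ccc(Cl)cc3)CS4)ccc2c1`: 5600 nM
- compound 3 `COc1ccc2cc(C(C)c3nnc4n3N=C(c3ccc(C(F)(F)F)cc3)CS4)ccc2c1`: 14800 nM

Compound 1 gives the lowest of the three numbers in this assay, but compound 2 sits within the scatter of it, so the two cannot be ranked; only compound 3 stands clearly apart from compound 1.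

Compound 4 `CC(C)Cc1ccc(C(C)c2nnc3n2N=C(c2ccc(F)cc2)CS3)cc1` is not yet measured. It differs from compound 1 by fluoro in place of methyl on an aromatic carbon, that is, 4-methylphenyl becomes 4-fluorophenyl.

Going by the values given here, no measured pair shows this exact change. Among the compounds with values here, the one step at the same place, a 2.6-fold higher number from compound 2 to compound 3 (0.42 log units; beyond the scatter), shows that a substituent swap on this aryl can move the number modestly. Fluoro for methyl is a smaller swap than trifluoromethyl for chloro, so the expected step is smaller still. Compound 4 is therefore expected to give about 5500 nM in this assay, with a range of 2500 nM to 12000 nM. The step this estimate means, a 1.1-fold higher number from compound 1 to compound 4 (0.04 log units; within the scatter), is expected to stay within the scatter.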

Compound 4, half-maximal inhibitory concentration: 7800 nM
The estimate for compound 4 lay 1.4-fold (0.15 log units) below the measured number; measured number inside the range.
By their numbers in this assay, from the lowest: compounds 1, 2, 4 and 3 (each within the scatter of the next, the first and the last beyond it).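

Fluoro in place of methyl on the aryl gives a 1.6-fold higher number from compound 1 to compound 4 (0.19 log units; within the scatter) in this assay and therefore does not separate the two compounds. Going by these compounds alone, this is the first direct reading of 4-methylphenyl to 4-fluorophenyl on the core of compound 1, and it shows that this exchange leaves the number within the usual scatter on that background. Within the data shown here, the only step at this place that goes beyond the scatter remains a 2.6-fold higher number from compound 2 to compound 3 (0.42 log units; beyond the scatter) on a different background, and no measurement at hand accounts for the result on compound 4.

Going by these compounds, whether an amine such as dimethylamino or a carboxylic acid at this place would move the number beyond the scatter stays open. Also open, on these data alone, is whether fluoro for methyl would give a similar small step on the background of compound 2.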